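The source may report more compounds than this note shows. Statements on the series, on what has been measured and on what is new or still open speak of the compounds shown alone.

Compound 1, `COc1cc(NC(=O)Nc2cc(Nc3cccc(C(C)(C)C)c3)ncn2)cc(OC)c1`, is one of three ureas built on the same core, the others being compound 2, `CC(C)(C)c1cccc(Nc2cc(NC(=O)Nc3c(Cl)cccc3Cl)ncn2)c1`, and compound 3, `CC(C)(C)c1ccc(Nc2cc(NC(=O)Nc3c(Cl)cccc3Cl)ncn2)cc1`. In a functional assay on HCC827 cells (Homo sapiens) for inhibition, read by MTT assay, with a stated time of 48 h, tested at 10 uM (on this read-out lower numbers stand for less inhibition and higher numbers for more inhibition at the one concentration tested (going by the name of the read-out)), compound 1 gives 48.7%, compound 2 gives 37.3% and compound 3 gives 42.3%. Among these three numbers compound 1 stands highest: its gap to compound 3 lies within the usual scatter, while its gap to compound 2, a number 11.4 percentage points lower from compound 1 to compound 2 (beyond the scatter), lies beyond it.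

Compound 4, `CCc1ccc(Nc2cc(NC(=O)Nc3cc(OC)cc(OC)c3)ncn2)cc1`, differs from compound 1 only at the nitrogen on the aromatic ring: 4-ethylphenyl in place of 3-(tert-butyl)phenyl on a nitrogen on an aromatic ring. For the measured compounds named here, no measured step alters this very place, so the measured change, which concerns the other nitrogen of the urea, bears on it only indirectly. Compounds 2 and 3, which differ in where the tert-butyl group sits on that ring, give numbers that lie within the scatter of each other. A step within the scatter is therefore expected from compound 1 to compound 4, with a number 4.7 percentage points lower from compound 1 to compound 4 (within the scatter). Compound 4 is expected to give 44% in this assay, between 30% and 58%.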

Compound 4, a percentage reported as inhibition, at one concentration (the size of the read-out at that concentration, not a potency): 66.2%
Compound 4: middle estimate off by 22.2 percentage points, on the low side; the whole stated range lies below it.
By their numbers in this assay, from the lowest: compounds 2, 3 and 1 (each within the scatter of the next, the first and the last beyond it); then compound 4.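

Changing the group on this nitrogen can shift the read-out beyond the scatter in this assay: 4-ethylphenyl in place of 3-(tert-butyl)phenyl gives a number 17.5 percentage points higher from compound 1 to compound 4 (beyond the scatter), and compound 4 now stands above all three earlier ureas. The earlier compounds shown here did not show this, since compound 2 at 37.3% and compound 3 at 42.3%, which differ only in where the tert-butyl group sits, lie within the scatter of each other. This one change alters both the alkyl group and its place on the ring, so the step cannot be assigned to either alone, and nothing available explains it.

Going by these compounds, it remains open whether 4-ethylphenyl would give a similar step alongside 2,6-dichlorophenyl on the other urea nitrogen. Also open, on these data alone, is how a longer chain, or an amine or carboxylic acid on this ring, would read out.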